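Swapping the aryl group on the hydrazone of a shared core

The compounds below may be only part of what the source reports. "The series", "measured", "known", "first", "only" and "open" are said of these compounds alone.

Measured compounds:
compound 1, `Cn1c(=O)c(=O)n(C2CCCC2)c2nc(N/N=C/c3ccc(O)cc3)ncc21`, > 100000 nM;
compound 2, `Cn1c(=O)c(=O)n(C2CCCC2)c2nc(N/N=C/c3ccc(S(C)(=O)=O)cc3)ncc21`, 84500 nM;
compound 3, `Cc1ccc(/C=N/Nc2ncc3c(n2)n(C2CCCC2)c(=O)c(=O)n3C)cc1C`, 30200 nM.

All three share one core and differ only in the aryl group on a carbon with a double bond to nitrogen. In a functional assay on A549 cells (Homo sapiens) for antiproliferative activity, read by MTT assay (on this read-out lower numbers stand for stronger inhibition and higher numbers for weaker inhibition), compound 1 reaches only the limit (the limit of > 100000 nM in this assay, at which 1 of the 3 values shown sits), so it is not a number. Compound 2 gives a number, and the step of an at least 1.1-fold lower number from compound 1 to compound 2 (0.07 log units; that floor lies within the scatter) stays within scatter. Compound 3 has the lowest number of the two numbers shown, and the step of a 2.8-fold lower number from compound 2 to compound 3 (0.45 log units; beyond the scatter) is modest, while an at least 3.3-fold lower number from compound 1 to compound 3 (0.51 log units; beyond the scatter) is at least modest.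

Compound 4, `Cn1c(=O)c(=O)n(C2CCCC2)c2nc(N/N=C/c3ccccc3Cl)ncc21`, is not yet measured. Its change is 2-chlorophenyl in place of 3,4-dimethylphenyl on a carbon with a double bond to nitrogen. Both measured steps bearing on it also swapped this aryl group and moved the number only modestly, so the expected step of a 1.0-fold lower number from compound 3 to compound 4 (0.00 log units; within the scatter) is small, in either direction. Compound 4 is therefore expected to give about 30000 nM in this assay, between 10000 nM and 100000 nM.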

Compound 4, half-maximal inhibitory concentration: 9860 nM
Beside the measured number, compound 4's estimate is 3.0-fold (0.48 log units) above it, outside the stated range (below it).
By their numbers in this assay, from the lowest: compound 4; then compound 3; then compound 2. At a limit, above all of these: compound 1.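

In this assay, one more swap of the aryl group on a carbon with a double bond to nitrogen still lowers the number, with a 3.1-fold lower number from compound 3 to compound 4 (0.49 log units; beyond the scatter), so 3,4-dimethylphenyl does not mark the low end at this position. Set against the sulfonyl-bearing aryl group, 2-chlorophenyl gives an 8.6-fold lower number from compound 2 to compound 4 (0.93 log units; beyond the scatter), a wider spread than the earlier numbers showed, and compound 4 now has the lowest number of the set. The step of an at least 10-fold lower number from compound 1 to compound 4 (1.00 log units; beyond the scatter) is only a floor, as compound 1 stands at a limit and not a number: the limit of > 100000 nM in this assay, at which 1 of the 4 values shown sits.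

Whether the lower number follows the chlorine itself or its place on the ring stays open, since 2-fluorophenyl, 2-methylphenyl and 4-chlorophenyl do not appear among these compounds. How an aryl group carrying an amine or a carboxylic acid would behave here is also unknown.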